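The source may hold more compounds than are shown below. What is called first, only, known or untested is meant among the compounds shown, and "the series" means these compounds.

Measured in a functional assay on HT-29 cells (Homo sapiens) for inhibition, read by CellTiter-Glo, with a stated time of 72 h; on this read-out lower numbers stand for higher toxicity in this test and higher numbers for lower toxicity in this test:
- compound 1 `CC1=C(CC(=O)N2CCN(c3ccncc3)CC2)c2cc(F)ccc2/C1=C\c1nc2ccccc2s1` gives 5250 nM
- compound 2 `CC1=C(CC(=O)N(C)CCN(C)S(=O)(=O)c2ccccc2)c2cc(F)ccc2/C1=C\c1ccc([S+](C)[O-])cc1` gives 6090 nM

Among the compounds with values here, compound 2 lies within the scatter of compound 1, and the two differ in more than one place, so no measured pair isolates a single change. Compound 3 `CC1=C(CC(=O)N(C)CCN(C)S(=O)(=O)c2ccc3ccccc3c2)c2cc(F)ccc2/C1=C\c1ccc([S+](C)[O-])cc1` carries naphthalen-2-yl in place of phenyl on a sulfonyl sulfur. The expectation therefore rests on this structural change alone, and it is weakly founded. A small move toward lower numbers in this assay is expected, estimated as a 2.2-fold lower number from compound 2 to compound 3 (0.34 log units; beyond the scatter). The estimated value for compound 3 is 2800 nM, with a range of 1000 nM to 8000 nM.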

Compound 3, half-maximal cytotoxic concentration: 6350 nM
Compound 3: middle estimate off by 2.3-fold (0.36 log units), on the low side; the measured number falls inside the stated range.
By their numbers in this assay, from the lowest: compounds 1, 2 and 3 (each within the scatter of the next).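

In this assay, within the data shown here, the exchange of phenyl for naphthalen-2-yl on a sulfonyl sulfur gives a 1.0-fold higher number from compound 2 to compound 3 (0.02 log units; within the scatter) and stays within the scatter, the first comparison that isolates one change. At this place, with the sulfonamide nitrogen as the sulfur's other neighbour, the second six-membered aromatic ring leaves the read-out unresolved from that of the phenyl compound. No supporting measurement bears on this result.

Open, from the compounds shown here alone, is how a non-aromatic group on the sulfonyl sulfur, such as methyl or cyclohexyl, would read. Also open, going by these compounds, is whether a phenyl ring carrying an amine or a carboxylic acid would separate from compound 2.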